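A Dichlorophenyl Swap on a Piperidine Amide Agonist

A few compounds are considered here, and "the series" means these few. Any claim that something is new, unique, unknown or untested is made for them only; others in the source may bear on it.

Of the compounds shown here, three have been tested in a functional assay on HEK293 cells for agonist activity at D(4) dopamine receptor (Homo sapiens), read by FLIPR; a higher number here means that more compound is needed for the effect, a lower number that less compound is needed. Compound 1, `Cc1cc(F)ccc1NC(=O)CN1CCC(c2cccc[n+]2[O-])CC1`, gives 60 nM. Compound 2, `c1ccc(C2CCN(Cc3nc4ccccc4[nH]3)CC2)nc1`, gives 12 nM, and compound 3, `O=C(NCN1CCC(c2cccc[n+]2[O-])CC1)c1ccccc1`, gives 532 nM. Compound 1 therefore holds the second highest number of the three: compound 2 sits at a lower number, compound 3 at a higher one, and both gaps lie beyond the usual scatter.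

Compound 4, `O=C(CN1CCC(c2cccc[n+]2[O-])CC1)Nc1cccc(Cl)c1Cl`, has not been measured yet. It differs from compound 1 in one place: 2,3-dichlorophenyl in place of 4-fluoro-2-methylphenyl on an amide-type nitrogen. The halogen and methyl pattern on the aromatic ring attached to the amide-type nitrogen is exchanged for two chlorines, while everything else, including the shared core of compound 1, stays the same. Among the measured compounds shown here, with no measured pair showing this kind of exchange, the expected step from compound 1 to compound 4 in this assay is small, a 1.2-fold lower number from compound 1 to compound 4 (0.08 log units; within the scatter), in no clear direction beyond the scatter. Compound 4 is estimated at 50 nM, within a range from 15 nM to 200 nM.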

Compound 4, half-maximal effective concentration: 180 nM
Compound 4: middle estimate off by 3.6-fold (0.56 log units), on the low side; measured number inside the range.
By their numbers in this assay, from the lowest: compound 2; then compound 1; then compound 4; then compound 3.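

Among the compounds shown here, this is the first pair that differs in one place only, so it gives the first direct reading of the aromatic ring on the amide-type nitrogen. In this assay, putting 2,3-dichlorophenyl in place of 4-fluoro-2-methylphenyl gives a 3.0-fold higher number from compound 1 to compound 4 (0.48 log units; beyond the scatter), so the number responds to what this ring carries, even though both groups have the same heavy-atom count and the same kind of ring. Nothing available explains why the number moves in this direction.

This single pair cannot show how much each ring substituent contributes, since the fluorine, methyl and two chlorines all change together. An unsubstituted phenyl ring, or a ring carrying one chlorine or one methoxy group, on the same amide-type nitrogen would help separate those contributions.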